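Compound 4 against the cytotoxicity limit

The compounds below may be only part of what the source reports. "The series", "measured", "known", "first", "only" and "open" are said of these compounds alone.

Compound 1 `COc1ccc([C@H]2CC(=O)N(C(=O)c3ccccc3)C2)cc1OC1CCCC1` carries benzoyl on the amide-type nitrogen in a ring. In a functional assay on HEK293 cells (Homo sapiens) for cytotoxicity (on this read-out lower numbers stand for higher toxicity in this test and higher numbers for lower toxicity in this test), compound 1 gives > 10000 nM, which is a limit and not a number. In this assay compound 2 `COc1ccc([C@H]2CC(=O)N(c3ccccc3C)C2)cc1OC1CCCC1`, with 2-methylphenyl on that nitrogen, gives > 10000 nM, also a limit. In this assay compound 3 `COc1ccc([C@H]2CC(=O)N(c3cccc(C)c3)C2)cc1OC1CCCC1`, with 3-methylphenyl there, gives > 10000 nM, again a limit. The evidence so far is the limit of > 10000 nM in this assay, at which 3 of the 3 values shown sit, so compound 3 has no number of its own.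

Compound 4 `COc1ccc([C@H]2CC(=O)N(c3cccc(NC(=O)C(C)=O)c3)C2)cc1OC1CCCC1` follows by (acetylcarbonyl)amino in place of methyl on an aromatic carbon, meta to a large group. The measured steps that bear on this are a step that the two limits leave unreadable from compound 1 to compound 2, a step that the two limits leave unreadable from compound 1 to compound 3 and a step that the two limits leave unreadable from compound 2 to compound 3. None gives a size or a direction, and none involves the entering group. In this assay no step beyond the scatter is therefore expected, and the estimated step is a step that the limit leaves unreadable from compound 3 to compound 4. Compound 4 is expected at 15000 nM, with an estimated range of 5000 nM to 50000 nM.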

Compound 4, half-maximal cytotoxic concentration: > 10000 nM
Compound 4: only a limit was reported; the forecaster's own chance of this, stated with the estimate: 80%; the middle value is on the limit's open side.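

In this assay, among these compounds, compound 4 gives > 10000 nM, a limit and not a number, so no step from compound 3 to compound 4 can be read. The compounds shown leave open where any of their half-maximal cytotoxic concentrations lies, and whether (acetylcarbonyl)amino in place of methyl changes it.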